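Benzylamino in place of hydroxymethyl: the bromo variant

A few compounds are considered here, and "the series" means these few. Any claim that something is new, unique, unknown or untested is made for them only; others in the source may bear on it.

Compound 3 `COc1cc(Oc2cccc(Nc3ccccc3)c2)cc(OC)c1CCO` carries hydroxymethyl on the saturated chain carbon bound to an aromatic carbon. In a functional assay on HCT-116 cells (Homo sapiens) for inhibition, read by MTT assay, with a stated time of 72 h (on this read-out lower numbers stand for stronger inhibition and higher numbers for weaker inhibition), compound 3 gives only a limit, > 20000 nM, which is the limit of > 20000 nM in this assay, at which 1 of the 3 values shown sits. Compound 1 `COc1ccc(CNCc2c(OC)cc(Oc3cccc(Nc4ccccc4)c3)cc2OC)cc1` gives 2620 nM and compound 2 `COc1cc(Oc2cccc(Nc3ccccc3)c2)cc(OC)c1CNCc1ccc(C)cc1` gives 13800 nM; between them stands a 5.3-fold higher number from compound 1 to compound 2 (0.72 log units; beyond the scatter). Towards compound 3 the steps are an at least 7.6-fold higher number from compound 1 to compound 3 (0.88 log units; beyond the scatter) and an at least 1.4-fold higher number from compound 2 to compound 3 (0.16 log units; that floor lies within the scatter). Compound 4 `COc1cc(Oc2cccc(Nc3ccccc3)c2)cc(OC)c1CNCc1ccc(Br)cc1` differs from compound 3 by (4-bromobenzyl)amino in place of hydroxymethyl on a saturated chain carbon bound to an aromatic carbon, a return to a benzylamino group. Both measured benzylamino analogues, compound 1 and compound 2, give numbers inside the measured range, so compound 4 is expected to do the same. The step expected is an at least 3.3-fold lower number from compound 3 to compound 4 (0.52 log units; beyond the scatter). For compound 4 the estimate is 6000 nM, between 1500 nM and 20000 nM.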

Compound 4, half-maximal inhibitory concentration: 6230 nM
The estimate for compound 4 lay 1.0-fold (0.02 log units) below the measured number; the range from low to high includes it.
By their numbers in this assay, from the lowest: compound 1; then compound 4; then compound 2. At a limit, above all of these: compound 3.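

In this assay the return to a benzylamino group holds with a third substituent on the aromatic carbon, giving an at least 3.2-fold lower number from compound 3 to compound 4 (0.50 log units; beyond the scatter) as a floor only. Bromo in place of methyl gives a 2.2-fold lower number from compound 2 to compound 4 (0.35 log units; beyond the scatter) and bromo in place of methoxy gives a 2.4-fold higher number from compound 1 to compound 4 (0.38 log units; beyond the scatter) so bromo falls in the middle of the three substituents in this series. That floor rests on a limit for compound 3: the limit of > 20000 nM in this assay, at which 1 of the 4 values shown sits.

On these data alone, whether chloro, trifluoromethyl or nitrile on that aromatic carbon would fall within the same span remains open. So does whether a simple dimethylamino group in place of the (4-bromobenzyl)amino would keep any of the gain over hydroxymethyl.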